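A few compounds are considered here, and "the series" means these few. Any claim that something is new, unique, unknown or untested is made for them only; others in the source may bear on it.

Of the compounds shown here, two that share one core have been tested in a functional assay (aorta) with Rattus norvegicus as the target; on this read-out lower numbers stand for stronger inhibition and higher numbers for weaker inhibition. Compound 1 `CC1(C)Oc2ccc(C#N)cc2[C@@H](/N=C(\NC#N)Nc2ccc(Cl)cc2)[C@@H]1O` gives 1800 nM in this assay, and compound 2 `CC1(C)Oc2ccc(C#N)cc2[C@@H](/N=C(\NC#N)Sc2ccccc2)[C@@H]1O` gives 4900 nM. Among these two numbers compound 2 stands at the higher end, the step being a 2.7-fold higher number from compound 1 to compound 2 (0.43 log units; beyond the scatter). Compound 3 `CC1(C)Oc2ccc(C#N)cc2[C@@H](/N=C(\NC#N)Nc2ccc(Cl)c(F)c2)[C@@H]1O` has not yet been measured. It differs from compound 2 in one place: (4-chloro-3-fluorophenyl)amino in place of phenylsulfanyl on a carbon with a double bond to nitrogen. Within the data shown here, only one measured step bears on this change, a 2.7-fold higher number from compound 1 to compound 2 (0.43 log units; beyond the scatter), and it is close to the reverse of the present one: compound 1 carries (4-chlorophenyl)amino where compound 2 carries phenylsulfanyl. Returning to an arylamino group of that kind, here with an added fluorine, is therefore expected to lower the number by a comparable amount, so the step is estimated as a 3.1-fold lower number from compound 2 to compound 3 (0.49 log units; beyond the scatter). Compound 3 is accordingly estimated at 1600 nM, with a likely range from 600 nM to 4200 nM.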

Compound 3, half-maximal inhibitory concentration: 1660 nM
Estimate against measurement, compound 3: 1.0-fold (0.02 log units) below; low and high end bracket the measured number.
By their numbers in this assay, from the lowest: compounds 3 and 1 (each within the scatter of the next); then compound 2.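

In this assay, (4-chloro-3-fluorophenyl)amino in place of phenylsulfanyl gives a 3.0-fold lower number from compound 2 to compound 3 (0.47 log units; beyond the scatter), so the advantage of an arylamino group over phenylsulfanyl at this carbon now rests on two compounds rather than on compound 1 alone. Fluoro in place of hydrogen on an aromatic carbon gives a 1.1-fold lower number from compound 1 to compound 3 (0.04 log units; within the scatter), which lies within the scatter, so this added fluorine leaves no readable mark on the number in this assay. No measurement at hand explains either step.

Both arylamino compounds carry halogens on the ring while compound 2 carries none. The amine nitrogen and the halogens differ together in these comparisons, and the data do not separate them; a plain phenylamino group would tell them apart. On these data alone, how a methoxy group on that ring or an open-chain group such as butylamino would fare also remains unknown.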